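The source may report more compounds than this note shows. Statements on the series, on what has been measured and on what is new or still open speak of the compounds shown alone.

Measured so far in a functional assay, read by spectrophotometry, with a stated time of 3 min; on this read-out higher numbers stand for weaker inhibition and lower numbers for stronger inhibition:

- compound 1, `Nc1ccccc1/N=C\c1cc(=O)oc2cc(OCc3ccccc3)ccc12`: 9250 nM
- compound 2, `O=c1cc(/C=N\c2ccc(O)cc2)c2c(OCc3ccccc3)cc(OCc3ccccc3)cc2o1`: 3570 nM
- compound 3, `O=c1cc(/C=N\Nc2ccc([N+](=O)[O-])cc2[N+](=O)[O-])c2c(OCc3ccccc3)cc(OCc3ccccc3)cc2o1`: "not active" (no number reported)

Compound 1 shows the highest number of the two compounds that gave a number in this assay; the nearest is compound 2, whose lower number lies beyond the usual scatter. Compound 3 gave no number in this assay and is recorded as not active. For the measured compounds named here, no single-point step between any two measured compounds is available, so the series offers no measured guide for the size of any change.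

Compound 4, `O=c1cc(/C=N\O)c2ccc(OCc3ccccc3)cc2o1`, is still to be measured. Compared with compound 1 it carries hydroxy in place of 2-aminophenyl on a double-bonded nitrogen. Both compounds share the core with one benzyloxy group, and the group on the double-bonded nitrogen is the only place of difference.

Going by the values given here, with no measured step to lean on, the expectation for compound 4 rests on the number for compound 1 alone. The step of a 1.3-fold higher number from compound 1 to compound 4 (0.11 log units; within the scatter) is expected to be small, possibly none beyond the scatter, with a slight lean toward a higher number. Compound 4 is therefore estimated at 12000 nM in this assay, within a range from 4000 nM to 40000 nM.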

Compound 4, half-maximal inhibitory concentration: 22800 nM
Estimate against measurement, compound 4: 1.9-fold (0.28 log units) below; the measured number falls inside the stated range.
By their numbers in this assay, from the lowest: compound 2; then compound 1; then compound 4.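

In this assay, the group on the double-bonded nitrogen now has its first measured step: hydroxy in place of 2-aminophenyl gives a 2.5-fold higher number from compound 1 to compound 4 (0.39 log units; beyond the scatter), a modest change that lies beyond the scatter. The position therefore responds to this exchange on the core with one benzyloxy group, although the size of the step stays modest even with the six-membered aromatic ring of carbon gone and compound 4 still gives a number. The counts of hydrogen-bond donors and acceptors are the same on both sides of the change, and no measurement at hand accounts for the step.

This single step cannot separate the loss of the ring from the arrival of the hydroxy, so a plain phenyl or a methoxy on the same nitrogen would be needed to divide the two. Compounds 2 and 3 differ from compound 1 in more than one place, which leaves open how a second benzyloxy group on the core bears on the number, and whether the step holds on that core.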